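A few compounds are considered here, and "the series" means these few. Any claim that something is new, unique, unknown or untested is made for them only; others in the source may bear on it.

Measured so far:
- Compound 1 `Cc1cc(N)cc(C)c1Oc1cc(Nc2ccc(C#N)cc2)c(N)cc1C(F)(F)F`: 15800 nM
- Compound 2 `Cc1cc(CCC#N)cc(C)c1Oc1cc(Nc2ccc(C#N)cc2)c(N)cc1C(F)(F)F`: > 7100 nM

The read-out here is an ADME assay on TZM cells (Homo sapiens) for cytotoxicity, read by XTT assay, with a stated time of 4 days; on this read-out lower numbers stand for higher toxicity in this test and higher numbers for lower toxicity in this test. In this assay compound 1 gives 15800 nM, a real number.

Compound 2 stands only at a limit, > 7100 nM, and not at a measured number.

Compound 3 `Cc1cc(C#N)cc(C)c1Oc1cc(Nc2ccc(C#N)cc2)c(N)cc1C(F)(F)F` carries cyano in place of 2-cyanoethyl on an aromatic carbon, meta to two methyl groups and para to a large group: cyano in place of 2-cyanoethyl on an aromatic carbon. The rest of the structure stays the same.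

Going by the values given here, only one measured step touches this position, a step that the limit leaves unreadable from compound 1 to compound 2. Its size cannot be read, so it offers no size or direction to carry over. Among the compounds with values here, the only firm number nearby is the one for compound 1, 15800 nM, so the expectation is anchored there, with a wide margin.

The expected step in this assay is a step that the limit leaves unreadable from compound 2 to compound 3, and the measured data support no direction for it.

For compound 3 the estimated value is 12000 nM, with an expected range from 4000 nM to 35000 nM.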

Compound 3, half-maximal cytotoxic concentration: 13300 nM
Estimate against measurement, compound 3: 1.1-fold (0.04 log units) below, within the range that was stated.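

In this assay, putting cyano in place of amino on the aromatic carbon that lies meta to two methyl groups is a 1.2-fold lower number from compound 1 to compound 3 (0.07 log units; within the scatter), so the two compounds cannot be told apart in this test. Going by these compounds alone, this is the only step at this position whose size can be read, and it gives this position its first comparison between two real numbers: swapping one of these small groups for the other leaves the cell toxicity reading unchanged within the normal noise of the test. The steps that involve compound 2 cannot be read, because compound 2 gives only a limit and not a measured number: the limit of > 7100 nM in this assay, at which 1 of the 3 values shown sits.

From the compounds shown here alone, it therefore remains open whether 2-cyanoethyl reads differently from cyano or amino on this carbon, since a limit cannot settle that comparison. Two readable groups at one position also say little about other groups there, so a carboxylic acid, a dimethylamino group or a longer chain ending in a nitrile could match these readings or depart from them, and the compounds shown do not tell which.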